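Swapping the Fluorophenyl Arm for a Methylphenylethyl Chain

This account rests on a few compounds, and the source may have more. Where it says the series, first, only, none or still open, it means among the compounds named here.

Compound 1 `CC(C(=O)NCc1ccc(C(F)(F)F)nc1-c1ccccc1F)c1ccc(NS(C)(=O)=O)c(F)c1` is the starting point here. For the measured compounds named here, in an assay on CHO cells for antagonist activity at transient receptor potential cation channel subfamily V member 1 (Homo sapiens), read by FLIPR (on this read-out higher numbers stand for weaker inhibition and lower numbers for stronger inhibition), compound 1 gives 63.3 nM, the highest of the two numbers known so far. Going by the values given here, its one measured partner is compound 2 `COc1ccc(-c2nc(C(F)(F)F)ccc2CNC(=O)C(C)c2ccc(NS(C)(=O)=O)c(F)c2)cc1OC`, which in this assay gives 25.6 nM; that change, 3,4-dimethoxyphenyl in place of 2-fluorophenyl on an aromatic carbon, brought a 2.5-fold lower number from compound 1 to compound 2 (0.39 log units; beyond the scatter). Compound 3 `Cc1ccc(CCc2nc(C(F)(F)F)ccc2CNC(=O)C(C)c2ccc(NS(C)(=O)=O)c(F)c2)cc1` has not yet been measured. It differs from compound 1 by 2-(4-methylphenyl)ethyl in place of 2-fluorophenyl on an aromatic carbon. Among the compounds with values here, the same place was altered in the step to compound 2, so that step is the only guide, and it shows a modest shift; the group entering compound 3 resembles neither earlier group, so the direction is open. A step close to the scatter is expected for compound 3, a 1.3-fold higher number from compound 1 to compound 3 (0.10 log units; within the scatter). Compound 3 is therefore estimated at 80 nM, with a range from 20 nM to 320 nM.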

Compound 3, inhibition constant: 0.6 nM
Compound 3: the middle estimate sits 130-fold (2.12 log units) above what was measured, and the stated range ends above it.
By their numbers in this assay, from the lowest: compound 3; then compound 2; then compound 1.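

In this assay this position proves able to carry far more change than the first pair suggested: the 2-(4-methylphenyl)ethyl group gives much larger steps (a 110-fold lower number from compound 1 to compound 3 (2.02 log units; beyond the scatter); a 43-fold lower number from compound 2 to compound 3 (1.63 log units; beyond the scatter)) than the earlier one (a 2.5-fold lower number from compound 1 to compound 2 (0.39 log units; beyond the scatter)). The entering group still holds a six-membered aromatic ring of carbon only, as 2-fluorophenyl does, so the ring type is not what is new; what changes is the ethyl chain, the added methyl group and the lost fluorine. Nothing available here explains why this change has so large an effect.

Still open, going by these compounds, is which of those three changes matters most, and an unsubstituted 2-phenylethyl group would help separate them. Also open, on these data alone, is how a longer chain such as 3-phenylpropyl, or an amine within the chain, would behave at this position.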